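Replacing the tetrazole with isopropyl in a weak series

The source may hold more compounds than are shown below. What is called first, only, known or untested is meant among the compounds shown, and "the series" means these compounds.

Compound 1 `CCn1nnc(C(/C=C/[C@@H](O)C[C@@H](O)CC(=O)O)=C(c2ccc(F)cc2)c2ccc(F)cc2)n1` and compound 2 `CC(C)n1nnc(C(/C=C/[C@@H](O)C[C@@H](O)CC(=O)O)=C(c2ccc(F)cc2)c2ccc(F)cc2)n1` share one core. In an assay for inhibition of 3-hydroxy-3-methylglutaryl-coenzyme A reductase (Rattus norvegicus) (a lower number here means a stronger inhibitor, a higher number a weaker inhibitor), compound 1 gives 200000 nM. For compound 2, > 300000 nM is a limit of this assay rather than a number, so compound 2 sits at the limit of > 300000 nM in this assay, at which 1 of the 2 values shown sits. Going by the values given here, the only measured step, an at least 1.5-fold higher number from compound 1 to compound 2 (0.17 log units; that floor lies within the scatter), changes a different position. Among the compounds with values here, compound 3 `CC(C)C(/C=C/[C@@H](O)C[C@@H](O)CC(=O)O)=C(c1ccc(F)cc1)c1ccc(F)cc1` differs from compound 2 by isopropyl in place of 2-isopropyl-2H-tetrazol-5-yl on a double-bonded chain carbon bound to two double-bonded chain carbons; no measured step bears on that change. The expected step is a number no higher from compound 2 to compound 3 (the limit leaves the size open). Compound 3 is therefore estimated at 300000 nM, in a range from 50000 nM to 1000000 nM.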

Compound 3, half-maximal inhibitory concentration: 230 nM
Beside the measured number, compound 3's estimate is 1300-fold (3.12 log units) above it; the measured number lies below the stated range.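

Moving from a tetrazolyl group to isopropyl at this place, on a double-bonded chain carbon bound to two double-bonded chain carbons, changes the reading in this assay far more than the earlier change on the tetrazole's alkyl group did. Isopropyl in place of 2-isopropyl-2H-tetrazol-5-yl gives an at least 1300-fold lower number from compound 2 to compound 3 (3.11 log units; beyond the scatter), and isopropyl in place of 2-ethyl-2H-tetrazol-5-yl gives an 870-fold lower number from compound 1 to compound 3 (2.94 log units; beyond the scatter). The first of these sizes is only a floor because compound 2 stands at a limit of the assay: the limit of > 300000 nM in this assay, at which 1 of the 3 values shown sits.

Going by these compounds, whether the difference belongs to isopropyl itself or to the loss of the tetrazolyl group stays open. On these data alone, how a cyclopropyl group, a phenyl ring or a longer chain would read at this place also remains unknown.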